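The source may report more compounds than this note shows. Statements on the series, on what has been measured and on what is new or still open speak of the compounds shown alone.

Measured compounds:
compound 1 `O=C(OCC(F)(F)F)c1ccsc1NC(=O)[C@@H]1CCCN1`, 109 ug/mL
compound 2 `COC(=O)c1sccc1NC(=O)[C@@H]1CCCN1`, 90.4 ug/mL
compound 3 `COC(=O)c1ccsc1NC(=O)[C@H]1CCCN1`, 91.4 ug/mL

Three esters sharing the same amide-linked core were tested in a functional assay on HeLa cells (Homo sapiens) for inhibition; a higher number here means a weaker inhibitor of growth, a lower number a stronger inhibitor of growth. Compound 1 gives 109 ug/mL, compound 2 gives 90.4 ug/mL and compound 3 gives 91.4 ug/mL. On these numbers compound 1 carries the highest figure of the three, but the nearest neighbour, compound 3, and the most distant, compound 2, both sit within the usual scatter of it, so nothing separates the three compounds in this assay; all of them are weak inhibitors of growth.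

Compound 4 `O=C(Oc1ccccc1)c1ccsc1NC(=O)[C@@H]1CCCN1` has not yet been measured in this assay. It differs from compound 1 in one place: phenyl in place of 2,2,2-trifluoroethyl on an oxygen next to a carbonyl group. For the measured compounds named here, no measured pair shows what such an exchange on the ester oxygen does here, and the three measured compounds, which vary their ester group and the placement of the substituents on the core, all land in the same narrow band. Compound 4 is therefore expected to stay close to compound 1, with the step of a 1.1-fold lower number from compound 1 to compound 4 (0.04 log units; within the scatter) estimated as none beyond the scatter. The estimate for compound 4 in this assay is 100 ug/mL, in the range from 40 ug/mL to 250 ug/mL.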

Compound 4, concentration for 50% growth inhibition: > 250 ug/mL
Compound 4: no number, only a limit; the forecaster's own chance of this, stated with the estimate: 15%; at least 2.5-fold (0.39 log units) between middle value and limit.
By their numbers in this assay, from the lowest: compounds 2, 3 and 1 (each within the scatter of the next). At a limit, above all of these: compound 4.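

In this assay, the group on the ester oxygen proves able to move the read-out: phenyl in place of 2,2,2-trifluoroethyl on an oxygen next to a carbonyl group gives an at least 2.2-fold higher number from compound 1 to compound 4 (0.36 log units; beyond the scatter), the only step shown that lies beyond the scatter. The earlier compounds shown here offered no pair differing in one place, so their shared narrow band said nothing about this position, whereas this single pair shows that the exchange goes with weaker inhibition of growth. The reading for compound 4 is a limit of the assay and not a number, so this step gives only a lower bound on the size of the change: the limit of > 250 ug/mL in this assay, at which 1 of the 4 values shown sits.

From the compounds shown here alone, what remains open is whether the loss of the 2,2,2-trifluoroethyl group or the arrival of the phenyl ring counts here, a question that a plain ethyl ester, a benzyl ester or the free carboxylic acid on the same core could help to settle. Going by these compounds, it is also open whether the same exchange would do the same on the core of compound 2 or with the other stereochemistry of compound 3.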